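The compounds below may be only part of what the source reports. "The series", "measured", "known", "first", "only" and "open" are said of these compounds alone.

In a functional assay on CCRF-CEM cells (Homo sapiens) for inhibition, read by cell counting, with a stated time of 96 h (a higher number here means a weaker inhibitor, a lower number a stronger inhibitor), compound 1 `COc1ccc(N(C)c2nc(C)nc3c2nc(C)n3C)cc1` gives 6200 nM. Among the compounds with values here, only one other compound has been measured so far: compound 2 `Cc1nc(N(C)c2ccc(OC(F)(F)F)cc2)c2nc(C)n(C)c2n1` gives 132000 nM, which leaves compound 1 with the lower number of the two. The measured step between them is a 21-fold higher number from compound 1 to compound 2 (1.33 log units; beyond the scatter), with trifluoromethyl in place of methyl on an oxygen on an aromatic ring.

Compound 3 `COc1ccc(N(C)c2nc(C)nc3c2ncn3C)cc1` keeps that oxygen-bound methyl and differs from compound 1 elsewhere: hydrogen in place of methyl on an aromatic carbon. In short, it has hydrogen in place of methyl on an aromatic carbon. Within the data shown here, the one measured step lies at another place in the molecule, so it does not show which way this new change will go. Among the measured compounds shown here, it shows only that a single change can move the number a long way in this assay. For the measured compounds named here, no measured step touches this place, so the best expectation is no clear shift, held with wide uncertainty. The expected change is a 1.6-fold lower number from compound 1 to compound 3 (0.19 log units; within the scatter). Compound 3 is estimated at 4000 nM, with an expected range from 500 nM to 30000 nM.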

Compound 3, half-maximal inhibitory concentration: 21000 nM
Beside the measured number, compound 3's estimate is 5.3-fold (0.72 log units) below it; low and high end bracket the measured number.
By their numbers in this assay, from the lowest: compound 1; then compound 3; then compound 2.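

In this assay, taking away this single methyl is not a neutral change (a 3.4-fold higher number from compound 1 to compound 3 (0.53 log units; beyond the scatter)). The earlier compounds shown here showed a large step only at the group on the oxygen; this result adds a second place where one change raises the number, the aromatic carbon between two ring nitrogen atoms, and the rise is modest but beyond the usual scatter. Compound 1, with methyl at both places, keeps the lowest number of the three, but no measurement available here explains why the methyl on this carbon matters.

As far as these compounds go, at this carbon, only methyl and hydrogen can be compared, so two points give a direction but not a trend, and it remains open whether a longer chain such as ethyl, or a different group such as an amine, would lower the number further or raise it again. From the compounds shown here alone, it is also open whether removing this methyl would have a similar effect when trifluoromethyl sits on the oxygen, since this step was read only with the methyl on the oxygen in place.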